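The compounds below may be only part of what the source reports. "The series", "measured", "known", "first", "only" and "open" are said of these compounds alone.

Going by the values given here, compound 2 `CCOC(=O)c1c(CSc2c(C)cccc2C)n(C)c2ccc(O)cc12` gives the lower of the two numbers measured so far in an assay for inhibition of Polyunsaturated fatty acid 5-lipoxygenase (Homo sapiens), read by HPLC, with a stated time of 10 min; on this read-out lower numbers stand for stronger inhibition and higher numbers for weaker inhibition: with 800 nM it sits below compound 1 `CCOC(=O)c1c(CSc2cccc(Cl)c2)n(C)c2ccc(O)cc12`, whose value in this assay is 3800 nM, and the step of a 4.8-fold lower number from compound 1 to compound 2 (0.68 log units; beyond the scatter) lies beyond the scatter.

Compound 3 `CCOC(=O)c1c(CSc2cc(C)cc(C)c2)n(C)c2ccc(O)cc12` is the next compound to be measured in this assay. It differs from compound 2 in one place: 3,5-dimethylphenyl in place of 2,6-dimethylphenyl on a sulfur. The two compounds share every atom and differ only in how the two methyl groups are joined to the phenyl ring.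

Among the compounds with values here, only one measured step exists, and it does not bear directly on this change: going from compound 1 to compound 2 exchanges a chloro-substituted phenyl for a dimethyl-substituted one, whereas the move to compound 3 keeps both methyl groups and the sulfur link and shifts only their placement on the ring. Within the data shown here, no measured pair shows what such a shift does. The expectation for compound 3 in this assay is therefore centred close to compound 2, as the step of a 1.9-fold higher number from compound 2 to compound 3 (0.27 log units; within the scatter) shows, with a wide range to cover either direction. Compound 3 is estimated at 1500 nM, between 400 nM and 6000 nM.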

Compound 3, half-maximal inhibitory concentration: 1800 nM
Beside the measured number, compound 3's estimate is 1.2-fold (0.08 log units) below it; measured number inside the range.
By their numbers in this assay, from the lowest: compound 2; then compound 3; then compound 1.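

Read in this assay, moving the two methyl groups on the phenyl ring attached to the sulfur is enough on its own to change the number: exchanging 2,6-dimethylphenyl for 3,5-dimethylphenyl gives a 2.3-fold higher number from compound 2 to compound 3 (0.35 log units; beyond the scatter) even though the atoms stay the same, so at this position the placement of the methyl groups counts as well as their presence. The 3,5-dimethylphenyl group nevertheless keeps part of the advantage over 3-chlorophenyl, with a 2.1-fold lower number from compound 1 to compound 3 (0.32 log units; beyond the scatter) and both steps are modest, which places the three groups in the order 2,6-dimethylphenyl, 3,5-dimethylphenyl, 3-chlorophenyl from lowest number to highest, an order that holds for these three compounds only. Nothing available explains why the placement of the methyl groups changes the number.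

The compounds shown leave open how an unsubstituted phenyl, or a phenyl carrying methoxy groups in place of the methyl groups, would compare at this position. They also leave open whether the difference between the two dimethylphenyl groups would persist with an oxygen or an amine in place of the sulfur, or with a carboxylic acid in place of the ethyl ester.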